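Trimethoxyphenyl-pyrazole chalcones: ketone aryl swap on compound 1

The source may hold more compounds than are shown below. What is called first, only, known or untested is meant among the compounds shown, and "the series" means these compounds.

Measured compounds:
compound 1 `COc1cc(-c2cc(/C=C/C(=O)c3ccc(Cl)c(Cl)c3)[nH]n2)cc(OC)c1OC`, > 100000 nM
compound 2 `COc1ccc(-c2cc(/C=C/C(=O)c3ccc(N)cc3)[nH]n2)cc1OC`, 10900 nM
compound 3 `COc1ccc(-c2cc(/C=C/C(=O)c3ccc(N)cc3)[nH]n2)cc1`, 2940 nM

All three were tested in a functional assay on UACC-62 cells (Homo sapiens) for inhibition, read by sulforhodamine B assay, with a stated time of 48 h; on this read-out lower numbers stand for stronger inhibition of growth and higher numbers for weaker inhibition of growth. Compound 1 gives only a limit there, > 100000 nM, so no number is known for it; it is the one entry of the three that sits at the limit of > 100000 nM in this assay, at which 1 of the 3 values shown sits. For the measured compounds named here, compound 2 and compound 3 give numbers, and the one step between measured compounds, a 3.7-fold lower number from compound 2 to compound 3 (0.57 log units; beyond the scatter), concerns hydrogen in place of methoxy on an aromatic carbon on the aryl attached to the shared core, not the aryl on the carbonyl carbon.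

The unmeasured compound 4 `COc1ccc(C(=O)/C=C/c2cc(-c3cc(OC)c(OC)c(OC)c3)n[nH]2)cc1OC` differs from compound 1 at the carbonyl side: 3,4-dimethoxyphenyl in place of 3,4-dichlorophenyl on a carbonyl carbon. Going by the values given here, no measured step bears directly on this exchange; the only recorded step is on the other aryl and modest in size. Compound 2, which carries the 3,4-dimethoxyphenyl that enters here but on the opposite end, gives 10900 nM, which shows that the group is compatible with measurable growth inhibition in this series.

Compound 4 is therefore expected to move from the limit of compound 1 to a measurable value, roughly an at least 3.3-fold lower number from compound 1 to compound 4 (0.52 log units; beyond the scatter), with considerable uncertainty. The estimate for compound 4 in this assay is 30000 nM, within a range of 5000 nM to 100000 nM.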

Compound 4, concentration for total growth inhibition: 3220 nM
The estimate for compound 4 lay 9.3-fold (0.97 log units) above the measured number; the whole stated range lies above it.
By their numbers in this assay, from the lowest: compounds 3 and 4 (each within the scatter of the next); then compound 2. At a limit, above all of these: compound 1.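

For the compounds shown here, on the carbonyl carbon, 3,4-dimethoxyphenyl in place of 3,4-dichlorophenyl gives an at least 31-fold lower number from compound 1 to compound 4 (1.49 log units; beyond the scatter) in this assay, so this position, which no earlier step touched, responds strongly to the aryl it carries. With the trimethoxyphenyl of compound 1 kept, compound 4 gives a measured 3220 nM, so that aryl on the shared core is compatible with growth inhibition, which compound 1 alone could not show. Compound 1 gives only a limit, so the step has a lower bound and its full size stays unknown: the limit of > 100000 nM in this assay, at which 1 of the 4 values shown sits.

With a single exchange at this position, the compounds shown cannot separate a contribution of the entering methoxy groups from one of the leaving chlorine atoms. Also open, on these data alone, are how a lone fluorine or a carboxylic acid on the aryl at the carbonyl carbon would read with the trimethoxyphenyl held fixed, and whether the same exchange gives a step of similar size with the other aryl of compound 2 or compound 3 on the shared core.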